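From 4-(methylsulfanyl)phenyl to 1H-pyrrol-2-yl in a growth assay

The compounds below may be only part of what the source reports. "The series", "measured", "known", "first", "only" and "open" are said of these compounds alone.

Of the compounds shown here, three with a shared core have been tested in a functional assay on DU-145 cells (Homo sapiens) for inhibition, read by trypan blue exclusion, with a stated time of 96 h; a lower number here means a stronger inhibitor of growth, a higher number a weaker inhibitor of growth. Compound 1 (`O=C(/C(=C\c1c(O)cc(O)cc1O)SCc1ccc(Cl)cc1)c1ccc(Cl)cc1`) returned only a limit of the assay, > 100000 nM.

Compound 2 (`Cc1ccc(/C=C(/SCc2ccc(Cl)cc2)C(=O)c2ccc(Cl)cc2)s1`) gives 50000 nM, and compound 3 (`CSc1ccc(/C=C(/SCc2ccc(Cl)cc2)C(=O)c2ccc(Cl)cc2)cc1`) gives 25000 nM. These two numbers lie within the scatter of each other, as a 2.0-fold lower number from compound 2 to compound 3 (0.30 log units; within the scatter) shows, so compound 3 shares its standing with compound 2. Against the limit of compound 1, the measured steps are an at least 4.0-fold lower number from compound 1 to compound 3 (0.60 log units; beyond the scatter) and an at least 2.0-fold lower number from compound 1 to compound 2 (0.30 log units; that floor lies within the scatter).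

Compound 4 (`O=C(/C(=C\c1ccc[nH]1)SCc1ccc(Cl)cc1)c1ccc(Cl)cc1`) has not yet been measured. It departs from compound 3 on a double-bonded chain carbon bound to a double-bonded chain carbon: 1H-pyrrol-2-yl in place of 4-(methylsulfanyl)phenyl on a double-bonded chain carbon bound to a double-bonded chain carbon.

All three measured steps change the group at this same place, so all of them bear on the question. Compound 2 is the closest guide, since replacing its 5-methylthiophen-2-yl gave a 2.0-fold lower number from compound 2 to compound 3 (0.30 log units; within the scatter). Compound 1 shows that a change here can also end at the limit. In this assay, no step beyond the scatter is therefore expected, with a slight lean towards a higher number. The expected step is a 1.6-fold higher number from compound 3 to compound 4 (0.20 log units; within the scatter). For compound 4 the estimate is 40000 nM, with an expected range of 13000 nM to 100000 nM.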

Compound 4, concentration for 50% growth inhibition: 10000 nM
Compound 4: the middle estimate sits 4.0-fold (0.60 log units) above what was measured; the whole stated range lies above it.
By their numbers in this assay, from the lowest: compound 4; then compounds 3 and 2 (each within the scatter of the next). At a limit, above all of these: compound 1.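

In this assay, going by these compounds alone, the 1H-pyrrol-2-yl group gives the first steps at this position, on a double-bonded chain carbon bound to a double-bonded chain carbon, that lie beyond the scatter with a measured number at both ends: a 2.5-fold lower number from compound 3 to compound 4 (0.40 log units; beyond the scatter) and a 5.0-fold lower number from compound 2 to compound 4 (0.70 log units; beyond the scatter). The second of these steps joins two five-membered aromatic rings, so ring size alone does not account for the values, and the identity of the ring matters at this place. The span at this position also widens to an at least 10-fold lower number from compound 1 to compound 4 (1.00 log units; beyond the scatter), which is only a floor, since compound 1 rests on a limit: the limit of > 100000 nM in this assay, at which 1 of the 4 values shown sits.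

The compounds shown leave open whether the hydrogen on the ring nitrogen of 1H-pyrrol-2-yl goes with the lower number, a question that a 1-methyl-1H-pyrrol-2-yl group or a furan-2-yl group at the same place would address. Nor do they show whether the advantage of 1H-pyrrol-2-yl holds when the rest of the shared core changes, as all four compounds differ only at this one place.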